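Fused bicycle in place of dimethylpyrazole: clearance expectation

The compounds below may be only part of what the source reports. "The series", "measured", "known", "first", "only" and "open" are said of these compounds alone.

Measured compounds:
compound 1 `CC(=O)N[C@@H]1CCC[C@H](C(=O)Nc2cc(-c3cnn(C)c3C)c(Cl)cn2)C1`, 10 uL/min
compound 2 `CC(=O)N[C@@H]1CCC[C@H](C(=O)Nc2cc(-c3cnn4c3CC(C)(C)CC4)ccn2)C1`, 35 uL/min

Two compounds share the acetamido-cyclohexane carboxamide core attached to a pyridine. In an ADME assay on cells (Hepatocyte, Rattus norvegicus) for metabolic stability, using equilibrium dialysis (on this read-out lower numbers stand for slow clearance and higher numbers for fast clearance), compound 1 gives 10 uL/min, the lowest of the two numbers. Compound 2 gives 35 uL/min in this assay, a gap from compound 1 that lies beyond the usual scatter; no single-point comparison is available between these two, so only their values stand side by side.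

The unmeasured compound 3 `CC(=O)N[C@@H]1CCC[C@H](C(=O)Nc2cc(-c3cnc4n3CC(C)(C)C4)c(Cl)cn2)C1` departs from compound 1 in one place: a group of 10 heavy atoms (8 carbon, 2 nitrogen; one five-membered non-aromatic ring with 1 hetero atom, one five-membered aromatic ring with 2 hetero atoms) in place of a group of 7 heavy atoms (5 carbon, 2 nitrogen; one five-membered aromatic ring with 2 hetero atoms), on an aromatic carbon. The change adds a five-membered non-aromatic ring to the aromatic part while keeping the chloro group on the core.

Among the measured compounds shown here, compound 2, the only other measured analogue, also carries a fused two-ring group and shows the higher value, so the expectation leans towards faster clearance for compound 3 than for compound 1. The step of a 2.0-fold higher number from compound 1 to compound 3 (0.30 log units; within the scatter) is expected to be modest, likely at the edge of the scatter rather than far beyond it. Compound 3 is estimated at 20 uL/min in this assay, within a range of 8 uL/min to 50 uL/min.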

Compound 3, intrinsic clearance in a liver preparation (reported as CLH), per the amount of preparation that the assay uses: 28 uL/min
Beside the measured number, compound 3's estimate is 1.4-fold (0.15 log units) below it; measured number inside the range.
By their numbers in this assay, from the lowest: compound 1; then compounds 3 and 2 (each within the scatter of the next).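

Among the compounds shown here, at the aromatic carbon ortho to a chloro group, exchanging the 1,5-dimethyl-1H-pyrazol-4-yl group for the fused group with its added five-membered non-aromatic ring gives a 2.8-fold higher number from compound 1 to compound 3 (0.45 log units; beyond the scatter) in this assay as the first change in this set that can be read in one place. This shows that the position is not indifferent to the group it carries: with the chloro group and the rest of the core held constant, this exchange alone moves the clearance number beyond the usual scatter, something the two earlier values could not show side by side. Nothing available here accounts for this step.

The compounds shown leave open whether the step follows from the added non-aromatic ring as such or from the two methyl groups it carries, and whether the same exchange would give a similar step without the chloro group. They also leave open how a smaller or quite different group at this carbon, such as an amine or a carboxylic acid, would read in this assay on the same core.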